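Turning the double bond of compound 3

The source may hold more compounds than are shown below. What is called first, only, known or untested is meant among the compounds shown, and "the series" means these compounds.

Measured in a functional assay on A549 cells (Homo sapiens) for cytotoxicity; a higher number here means that more compound is needed for the effect, a lower number that less compound is needed
- Compound 1 `COc1cc(/C=C/c2ccc(C(C)C)cc2)cc(OC)c1OC` gives 9.8 uM
- Compound 2 `CCOc1ccc(/C=C/c2cc(OC)c(OC)c(OC)c2)cc1` gives 1.7 uM
- Compound 3 `COc1cc(/C=C/c2ccc(SC)cc2)cc(OC)c1OC` gives 4.7 uM

Compound 3 holds the middle place, with 4.7 uM. The measured steps are a 2.1-fold lower number from compound 1 to compound 3 (0.32 log units; beyond the scatter) and a 2.8-fold higher number from compound 2 to compound 3 (0.44 log units; beyond the scatter). Compound 4 `COc1cc(/C=C\c2ccc(SC)cc2)cc(OC)c1OC` carries the same groups as compound 3, and the difference is this: the two compounds have the same atoms and bonds and differ only in configuration as drawn: 1 of 1 stereo elements differ; a double bond is drawn E in compound 3 and Z in compound 4. Within the data shown here, no measured step touches the double bond. Each one swaps a group on an aromatic carbon, the largest being a 5.8-fold lower number from compound 1 to compound 2 (0.76 log units; beyond the scatter), so none transfers directly. A lower number is expected, with much uncertainty, and the change may exceed those swaps. The expected step is a 9.4-fold lower number from compound 3 to compound 4 (0.97 log units; beyond the scatter). For compound 4 the estimated value is 0.5 uM, with an expected range of 0.03 uM to 5 uM.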

Compound 4, concentration for half-maximal effect: 1.9 uM
The estimate for compound 4 lay 3.8-fold (0.58 log units) below the measured number; the range from low to high includes it.
By their numbers in this assay, from the lowest: compounds 2 and 4 (each within the scatter of the next); then compound 3; then compound 1.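

In this assay, turning the double bond alone gives a 2.5-fold lower number from compound 3 to compound 4 (0.39 log units; beyond the scatter), so the geometry of this bond moves the number even when no group changes. The earlier steps shown here all swapped a group on an aromatic carbon and said nothing about this bond. The step can be assigned to the double bond alone because nothing else separates the pair: the fact that compounds 3 and 4 differ only in the configuration as drawn.

Going by these compounds, whether the same turn gives a step of similar size with ethoxy or isopropyl in place of methylsulfanyl stays open. So does how a Z compound carrying an amine or a carboxylic acid on that aromatic carbon would behave.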